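The source may report more compounds than this note shows. Statements on the series, on what has been measured and on what is new or still open speak of the compounds shown alone.

Compound 3 `COc1ccc(-c2cc(/C=C/C(=O)c3ccc(N)cc3)[nH]n2)cc1OC` gives 6870 nM in a functional assay on COLO 205 cells (Homo sapiens) for inhibition, read by sulforhodamine B assay, with a stated time of 48 h; on this read-out lower numbers stand for higher toxicity in this test and higher numbers for lower toxicity in this test. Compound 1 `COc1cc(-c2cc(/C=C/C(=O)c3ccc(N)cc3)[nH]n2)cc(OC)c1OC` differs from compound 3 by methoxy in place of hydrogen on an aromatic carbon; in this assay compound 1 gives 6420 nM, and a 1.1-fold lower number from compound 3 to compound 1 (0.03 log units; within the scatter). Compound 2 `COc1ccc(C(=O)/C=C/c2cc(-c3cc(OC)c(OC)c(OC)c3)n[nH]2)cc1OC` rests on another core; the difference between the cores of compound 2 and compound 3 is not broken down here. In this assay compound 2 gives 5920 nM, and a 1.1-fold lower number from compound 1 to compound 2 (0.04 log units; within the scatter). All three measured values sit within the scatter of one another, so no order among them can be drawn.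

Compound 4 `COc1cc(C(=O)/C=C/c2cc(-c3cc(OC)c(OC)c(OC)c3)n[nH]2)cc(OC)c1OC` has not yet been measured. It differs from compound 2 by methoxy in place of hydrogen on an aromatic carbon, the same change as that made from compound 3 to compound 1; these are the only two occurrences of the change among the compounds shown, and both sit at a place described in the same words.

Because the earlier step of a 1.1-fold lower number from compound 3 to compound 1 (0.03 log units; within the scatter) stayed within the scatter, the step expected from compound 2 to compound 4 in this assay is a 1.1-fold lower number from compound 2 to compound 4 (0.03 log units; within the scatter), of similar size. Compound 4 is therefore estimated at 5500 nM, with an expected range from 2800 nM to 11000 nM.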

Compound 4, concentration lethal to 50% of the cells: 5590 nM
Compound 4: middle estimate off by 1.0-fold (0.01 log units), on the low side; measured number inside the range.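

In this assay, within the data shown here, methoxy in place of hydrogen on an aromatic carbon gives a 1.1-fold lower number from compound 2 to compound 4 (0.02 log units; within the scatter), so the step on this core cannot be told apart from no step at all. Set beside the earlier step, the change reads alike on both cores: the same change on two cores in this assay, a 1.1-fold lower number (0.03 log units; within the scatter) from compound 3 to compound 1 and a 1.1-fold lower number (0.02 log units; within the scatter) from compound 2 to compound 4, 1.0-fold (0.00 log units) apart, within the scatter of two such steps

This shows that, on these two cores, the change leaves the number within the scatter each time, but it does not show that a real effect carries over, as neither step has a size that can be read, and two cores are too few to support a rule for the series.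

Open, on these data alone, is whether another group at this place, such as a hydroxyl, a fluorine or a carboxylic acid, would give a step beyond the scatter in this assay. Also open, as far as these compounds go, is whether the same lack of a readable step would hold on a core carrying an amine or a longer chain in place of a methoxy group.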